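Swapping an Acid Chain for 2,4-Difluorophenyl

The source may hold more compounds than are shown below. What is called first, only, known or untested is meant among the compounds shown, and "the series" means these compounds.

Of the compounds shown here, three sharing one core have been tested in a functional assay on RAW264.7 cells (Mus musculus), with a stated time of 3 days; on this read-out lower numbers stand for stronger inhibition and higher numbers for weaker inhibition. Compound 1 `COc1cnc(-c2ccccn2)nc1N(C)C1CCCC1` gives 180 nM. Compound 2 `COc1cnc(-c2ccccn2)nc1C1CCCC1` gives 1800 nM. Compound 3 `COc1cnc(-c2ccccn2)nc1NCCCC(=O)O` reaches only the limit of this assay, > 10000 nM. Inhibition weakens along both measured steps that end in the (3-carboxypropyl)amino group: an at least 55-fold higher number from compound 1 to compound 3 (1.74 log units; beyond the scatter) and an at least 5.5-fold higher number from compound 2 to compound 3 (0.74 log units; beyond the scatter). Compound 4 `COc1cnc(-c2ccccn2)nc1NCc1ccc(F)cc1F` differs from compound 3 by 2,4-difluorophenyl in place of 2-carboxyethyl on a saturated chain carbon bound to a nitrogen on an aromatic ring. The two measured steps show that the chain carrying 2-carboxyethyl goes with the weakest result here, and compound 4 no longer carries it, so a return toward stronger inhibition is expected. The expected step into compound 4 is an at least 11-fold lower number from compound 3 to compound 4 (1.04 log units; beyond the scatter). The estimated value for compound 4 in this assay is 900 nM, with a range from 150 nM to 6000 nM.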

Compound 4, half-maximal inhibitory concentration: 110 nM
Beside the measured number, compound 4's estimate is 8.2-fold (0.91 log units) above it, and the stated range ends above it.
By their numbers in this assay, from the lowest: compounds 4 and 1 (each within the scatter of the next); then compound 2. At a limit, above all of these: compound 3.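

In this assay, 2,4-difluorophenyl in place of 2-carboxyethyl gives an at least 90-fold lower number from compound 3 to compound 4 (1.95 log units; beyond the scatter), so this chain position can support good inhibition once the carboxylic acid is gone. Compound 3 stands at a limit of the assay, not at a measured number, so the true step could be larger: the limit of > 10000 nM in this assay, at which 1 of the 4 values shown sits.

Going by these compounds alone, compound 1 at 180 nM and compound 4 at 110 nM lie within the scatter of each other, so the cyclopentyl(methyl)amino group is not the only group giving a value in this range.

Still open, going by these compounds, is whether the gain comes from the ring, its fluorines or the loss of the carboxylic acid. An unsubstituted phenyl or a methyl ester in the same place would help separate these.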